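Replacing but-2-yn-1-yl with 2-phenylethynyl on the shared core

The compounds below may be only part of what the source reports. "The series", "measured", "known", "first", "only" and "open" are said of these compounds alone.

Compound 1 `C#Cc1cn(C2O[C@H](CO)[C@@H](O)[C@@H]2O)c(=O)[nH]c1=O` carries an unsubstituted triple bond on the shared core, and in a functional assay on L1210 cells (Mus musculus) (on this read-out lower numbers stand for stronger inhibition and higher numbers for weaker inhibition), compound 1 gives 45 ug/mL. Compound 2 `CCC#Cc1cn(C2O[C@H](CO)[C@@H](O)[C@@H]2O)c(=O)[nH]c1=O` is recorded only as a limit; in this assay compound 2 gives > 1000 ug/mL. That change is an at least 22-fold higher number from compound 1 to compound 2 (1.34 log units; beyond the scatter). Compound 3 `CC#CCc1cn([C@H]2C[C@H](O)[C@@H](CO)O2)c(=O)[nH]c1=O` likewise sits only at a limit, namely (the limit of > 1000 ug/mL in this assay, at which 2 of the 3 values shown sit); in this assay compound 3 gives > 1000 ug/mL. Compound 4 `O=c1[nH]c(=O)n([C@H]2C[C@H](O)[C@@H](CO)O2)cc1C#Cc1ccccc1` differs from compound 3 by 2-phenylethynyl in place of but-2-yn-1-yl on an aromatic carbon. Among the compounds with values here, the one measured step, from compound 1 to compound 2, shows that a group added on the triple-bonded carbon went with a large loss, and compound 3 already stands at the limit. Compound 4 is therefore expected to stay weak, with a step of a number no higher from compound 3 to compound 4 (the limit leaves the size open) expected to be none beyond the scatter. For compound 4 the estimate is 1000 ug/mL, ranging from 200 ug/mL to 3000 ug/mL.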

Compound 4, concentration for 50% inhibition: 494 ug/mL
Compound 4: middle estimate off by 2.0-fold (0.31 log units), on the high side; the range from low to high includes it.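

From the compounds shown here alone, the step from but-2-yn-1-yl to 2-phenylethynyl on the aromatic carbon reads an at least 2.0-fold lower number from compound 3 to compound 4 (0.30 log units; that floor lies within the scatter), so its true size stays unknown. Compound 4 gives a number in this assay rather than a limit, and it shows that a group on the triple-bonded carbon does not by itself hold a compound at the limit reached by compound 3: the limit of > 1000 ug/mL in this assay, at which 2 of the 4 values shown sit.

The compounds shown leave open whether this step truly exceeds the scatter. They also leave open how an amine or a carboxylic acid on the phenyl ring, or a longer chain on the triple bond, would read.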